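Notes on the step from compound 1 to compound 3

A few compounds are considered here, and "the series" means these few. Any claim that something is new, unique, unknown or untested is made for them only; others in the source may bear on it.

- compound 1 `COc1ccc(/C=N/NC(=O)c2cn(C3CC3)c3cc(N/N=C/c4ccc(OC)cc4)c(F)cc3c2=O)cc1`: <= 25000 nM
- compound 2 `COc1cc(/C=N/NC(=O)c2cn(C3CC3)c3cc(N/N=C/c4cc(OC)c(OC)c(OC)c4)c(F)cc3c2=O)cc(OC)c1OC`: <= 25000 nM

In a functional assay on L1210 cells (Mus musculus) for antiproliferative activity, read by MTT assay (a lower number here means a stronger inhibitor, a higher number a weaker inhibitor), compound 1 gives <= 25000 nM, which is a limit of the assay and not a number. Compound 2 carries a limit too. Within the data shown here, the series so far consists of the limit of <= 25000 nM in this assay, at which 2 of the 2 values shown sit.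

Compound 3 `COc1ccc(/C=N/NC(=O)c2cn(C3CC3)c3cc(N4CCNCC4)c(F)cc3c2=O)cc1` departs from compound 1 on an aromatic carbon, ortho to a fluoro group: a group of 6 heavy atoms (4 carbon, 2 nitrogen; one six-membered non-aromatic ring with 2 hetero atoms) in place of a group of 11 heavy atoms (8 carbon, 2 nitrogen, 1 oxygen; one six-membered aromatic ring of carbon only), on an aromatic carbon.

Among the measured compounds shown here, no measured step is available, so nothing beyond the scatter is expected, and the estimated change is a step that the limit leaves unreadable from compound 1 to compound 3.

For compound 3 the expected value is 15000 nM, with an estimated range of 3000 nM to 60000 nM.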

Compound 3, half-maximal inhibitory concentration: <= 25000 nM
Compound 3 ended at the assay's limit; the forecaster's own chance of this, stated with the estimate: 35%; the middle value lies beyond the limit too.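

No step from compound 1 to compound 3 can be read, since both values are limits of the assay and not numbers: the limit of <= 25000 nM in this assay, at which 3 of the 3 values shown sit.

The compounds shown leave open whether piperazin-1-yl differs in effect from the group it replaces.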